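The compounds below may be only part of what the source reports. "The series", "measured", "known", "first", "only" and "open" are said of these compounds alone.

Three compounds built on one shared core, each carrying two aziridin-1-yl groups, have been tested in a functional assay on L1210 cells (Mus musculus), with a stated time of 12 days; on this read-out higher numbers stand for higher potency (the scale is a negative logarithm) and lower numbers for lower potency. Compound 1, with the structure `CC1=C(N2CC2)C(=O)C(C2CCCCC2)=C(N2CC2)C1=O`, gives 5.39. Compound 2, with the structure `CCCC1=C(N2CC2)C(=O)C(CCOC(N)=O)=C(N2CC2)C1=O`, gives 5.23 in this assay, and compound 3, with the structure `CCC1=C(N2CC2)C(=O)C(C(COC(N)=O)OC)=C(N2CC2)C1=O`, gives 5.22. The three numbers lie within the scatter of one another, so none of the three can be set apart as more or less potent, and compound 1 simply sits among them with the numerically largest value.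

Compound 4, with the structure `COCCC1=C(N2CC2)C(=O)C(C)=C(N2CC2)C1=O`, has not yet been measured. It differs from compound 1 in one place: 2-methoxyethyl in place of cyclohexyl on a double-bonded ring carbon. No pair of measured compounds shows this change, so the size of the step in this assay has to be guessed from what is shown. Compounds 2 and 3, which carry oxygen-containing chains on the core, give values that stay within the scatter of compound 1, which suggests that a chain of this kind does not move the number far. For compound 4 the expected step is a number 0.14 log units lower from compound 1 to compound 4 (within the scatter), which is no step beyond the scatter. The value estimated for compound 4 in this assay is 5.25, with a range from 4.8 to 5.7.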

Compound 4, logarithm of the reciprocal of the active concentration, log(1/C): 5.42
The estimate for compound 4 lay 0.17 log units below the measured number; the measured number falls inside the stated range.
By their numbers in this assay, from the lowest: compounds 3, 2, 1 and 4 (each within the scatter of the next).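

In this assay, within the data shown here, the step of a number 0.03 log units higher from compound 1 to compound 4 (within the scatter) is the first direct reading of a single change on the shared core, and it lies within the scatter. At this double-bonded ring carbon, next to the ring atom that bears an aziridin-1-yl group, the ring of cyclohexyl can therefore give way to the open 2-methoxyethyl chain, which brings 1 hydrogen-bond acceptor, with no difference that can be told apart from repeat measurement. Nothing available explains why the number holds across so different a pair of groups.

This single step leaves open whether other groups at this ring carbon, such as an amine, a carboxylic acid, a phenyl ring or a much longer chain, would also leave the number within the scatter of compound 1. It also leaves open whether the same exchange would read the same with something other than methyl on the ring atom three ring bonds away, such as a propyl group.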